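The source may hold more compounds than are shown below. What is called first, only, known or untested is meant among the compounds shown, and "the series" means these compounds.

Measured compounds in a functional assay on MGC-803 cells (Homo sapiens) for antiproliferative activity, read by MTT assay, with a stated time of 48 h; a higher number here means a weaker inhibitor, a lower number a stronger inhibitor:
- compound 1, `COc1ccc(C(=O)/C=C/c2ccc(-n3cc(CSc4nnc(-c5ccccc5)c(-c5ccccc5)n4)nn3)cc2)cc1`: 36700 nM
- compound 2, `COc1ccc(-c2coc3cc(OCCCn4cc(CSc5nnc(-c6ccccc6)c(-c6ccccc6)n5)nn4)ccc3c2=O)cc1`: > 100000 nM, a limit of the assay
- compound 3, `O=c1ccc2ccc(OCCCn3cc(CSc4nnc(-c5ccccc5)c(-c5ccccc5)n4)nn3)cc2o1`: > 100000 nM, a limit of the assay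

Compound 1 is the only one of the three with a number rather than a limit. Compound 3 stands at the assay limit, and no number can be given for it; the same holds for compound 2, so two of the three entries sit where no value is resolved (the limit of > 100000 nM in this assay, at which 2 of the 3 values shown sit). Going by the values given here, compound 1 gives the one measured number, and it lies far from the potent end of this assay.

Compound 4, `O=c1cc(OCCCn2cc(CSc3nnc(-c4ccccc4)c(-c4ccccc4)n3)nn2)c2ccccc2o1`, is an isomer of compound 3: a group of 11 heavy atoms (9 carbon, 2 oxygen; one six-membered aromatic ring of carbon only, one six-membered aromatic ring with 1 hetero atom) in place of a group of 11 heavy atoms (9 carbon, 2 oxygen; one six-membered aromatic ring of carbon only, one six-membered aromatic ring with 1 hetero atom), on an oxygen on a saturated carbon. The linker, the triazole and the sulfur-bridged diphenyl-triazine are unchanged. Among the compounds with values here, no measured step exists for this kind of rearrangement, and nothing measured bears on it. With compound 3 at a limit, the step from compound 3 to compound 4 is expected to stay within the scatter, a step that the limit leaves unreadable from compound 3 to compound 4, most likely as another limit. For compound 4 the estimate is 120000 nM, ranging from 40000 nM to 400000 nM.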

Compound 4, half-maximal inhibitory concentration: > 100000 nM
Compound 4: a limit, no number; the forecaster's own chance of this, stated with the estimate: 80%; the middle value is on the limit's open side.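

Going by these compounds alone, compound 3 and compound 4 both stand at a limit of the assay, not at a number, so no step between them can be read in this assay: the limit of > 100000 nM in this assay, at which 3 of the 4 values shown sit. The compounds shown leave open whether this rearrangement of the group changes antiproliferative activity at all.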